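This account rests on a few compounds, and the source may have more. Where it says the series, first, only, none or still open, it means among the compounds named here.

Working notes on the series. Compound 1 `COc1nc2ccc(Br)cc2cc1C(c1ccccc1)n1cc(C2CC2)nn1` in an ADME assay on SK-OV-3 cells (Homo sapiens) for cytotoxicity, read by sulforhodamine B assay, with a stated time of 48 h, tested at 10 uM (on this read-out higher numbers stand for more inhibition at the one concentration tested (going by the name of the read-out) and lower numbers for less inhibition), gives 3.52%. Compound 2 `CCCCCCc1cn(C(c2ccccc2)c2cc3cc(Br)ccc3nc2OC)nn1` in this assay gives 7.17%, and compound 3 `COc1nc2ccc(Br)cc2cc1C(c1ccccc1)n1cc(CO)nn1` in this assay gives 3.23%. Compound 3 carries the lowest of the three numbers, but its nearest neighbour compound 1 and its furthest neighbour compound 2 both lie within the scatter of it, so no order among the three can be read from these values. The three recorded steps, a number 3.7 percentage points higher from compound 1 to compound 2 (within the scatter), a number 0.3 percentage points lower from compound 1 to compound 3 (within the scatter) and a number 3.9 percentage points lower from compound 2 to compound 3 (within the scatter), are all within the scatter; the whole range covered by the substituent variations at this part of the shared core stays narrow.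

Compound 4 `COc1nc2ccc(Br)cc2cc1C(c1ccccc1)n1cc(CCO)nn1` differs from compound 3 as follows: hydroxymethyl in place of hydroxy on a saturated chain carbon bound to an aromatic carbon. The step that bears most directly on this change is a number 3.9 percentage points lower from compound 2 to compound 3 (within the scatter), since it sits at the same place, and it was within the scatter; the step of a number 0.3 percentage points lower from compound 1 to compound 3 (within the scatter), which also installed the hydroxymethyl group, was within the scatter too. Nothing in the series points to a step beyond the scatter for one further saturated carbon at this place. The expected step is therefore a number 1.3 percentage points higher from compound 3 to compound 4 (within the scatter), none beyond the scatter. Compound 4 is estimated at 4.5%, with a range from -3% to 12%.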

Compound 4, a percentage reported as inhibition, at one concentration (the size of the read-out at that concentration, not a potency): 8.46%
Compound 4: the middle estimate sits 4 percentage points below what was measured; the measured number falls inside the stated range.
By their numbers in this assay, from the lowest: compounds 3, 1, 2 and 4 (each within the scatter of the next).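

In this assay, the change from hydroxymethyl to 2-hydroxyethyl gives a number 5.2 percentage points higher from compound 3 to compound 4 (within the scatter) and so, on these numbers, adds a saturated carbon to this chain without a step beyond the scatter. The 2-hydroxyethyl group also cannot be separated from the two groups without a hydroxy on the same position, with a number 4.9 percentage points higher from compound 1 to compound 4 (within the scatter) against cyclopropyl and a number 1.3 percentage points higher from compound 2 to compound 4 (within the scatter) against hexyl. Cyclopropyl, hexyl, hydroxymethyl and 2-hydroxyethyl thus give no order in this read-out at the one concentration tested, and the presence of the hydroxy group on the chain shows no readable effect here. No evidence beyond these numbers bears on this result.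

As far as these compounds go, whether an amine or a carboxylic acid at the end of this chain, or a longer chain ending in hydroxy, would give a step beyond the scatter remains open. Also open, from the compounds shown here alone, is whether replacing the bromo or methoxy group on the shared core, or the phenyl group, would take the read-out outside the narrow range seen so far.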